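A few compounds are considered here, and "the series" means these few. Any claim that something is new, unique, unknown or untested is made for them only; others in the source may bear on it.

Three compounds share one core and differ from one another at two places. Compound 1 `CSCc1cc(C(C)=O)c(O)cc1OCCCCCCC#N` carries a methylsulfanyl group, and in an assay on isolated protein for inhibition of leukotriene B4 receptor 1 (Homo sapiens), tested at 10 uM (a higher number here means more inhibition at the concentration tested (going by the name of the read-out), a lower number less inhibition), compound 1 gives 97%. For the measured compounds named here, compound 2 `COCc1cc(C(C)=O)c(O)cc1OCCCCCCC#N` in this assay gives 47%, and the step of a number 50 percentage points lower from compound 1 to compound 2 (beyond the scatter) is the only measured step between two compounds that differ in a single place. Compound 3 `C=CCc1cc(C(C)=O)c(O)cc1OCCCC#N` in this assay gives 47%, which is level with compound 2 at the digits shown; these two together form the lowest pair of the three, while compound 1 stands far higher.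

Compound 4 `C=CCc1cc(C(C)=O)c(O)cc1OCCCCCCC#N` differs from compound 3 by one change: 3-cyanopropyl in place of cyano on a saturated chain carbon, three bonds along the chain from an oxygen on an aromatic ring. Going by the values given here, no measured step covers this change. The step of a number 50 percentage points lower from compound 1 to compound 2 (beyond the scatter) concerns a different place and says nothing about chain length. Compounds 1 and 2 both carry the longer chain, yet their values lie far apart, so the effect of the chain alone cannot be read from them. The expected step of a number 13 percentage points higher from compound 3 to compound 4 (beyond the scatter) is therefore a modest rise with wide uncertainty. Compound 4 is estimated at 60%, within 35% to 85%.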

Compound 4, a percentage reported as inhibition, at one concentration (the size of the read-out at that concentration, not a potency): 97%
Beside the measured number, compound 4's estimate is 37 percentage points below it; measured number outside the range, above it.
By their numbers in this assay, from the lowest: compounds 2 and 3 (each within the scatter of the next); then compounds 1 and 4 (each within the scatter of the next).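

In this assay, the length of the nitrile-bearing chain now has a measured effect of its own: 3-cyanopropyl in place of cyano, on a saturated chain carbon three bonds along the chain from an oxygen on an aromatic ring, gives a number 50 percentage points higher from compound 3 to compound 4 (beyond the scatter). With the longer chain held fixed, vinyl in place of methoxy on a saturated chain carbon bound to an aromatic carbon gives a number 50 percentage points higher from compound 2 to compound 4 (beyond the scatter), whereas vinyl in place of methylsulfanyl at that carbon gives no change at the digits printed from compound 1 to compound 4 (within the scatter). So with the longer chain in place, the methoxy compound stands apart, while the vinyl and methylsulfanyl compounds read alike.

Nothing available explains why either change acts as it does. Going by these compounds, how a longer chain than that of compound 4, or a carboxylic acid in place of the nitrile, would read remains open.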